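This account rests on a few compounds, and the source may have more. Where it says the series, first, only, none or still open, it means among the compounds named here.

Compound 1 `Cc1ccc2c(=O)[nH]c(-c3ccccc3N(C)C)nc2c1` and compound 2 `Cc1ccc2c(=O)[nH]c(-c3cccc(OC(F)(F)F)c3)nc2c1` share one core and differ in the group carried on the aromatic ring. In a functional assay on HeLa cells (Homo sapiens) for cytotoxicity, read by MTT assay, with a stated time of 2 days (on this read-out higher numbers stand for weaker inhibition and lower numbers for stronger inhibition), compound 1 gives 43800 nM. For compound 2 this assay returns only a limit, > 50000 nM, so its reading sits at the limit of > 50000 nM in this assay, at which 1 of the 2 values shown sits, and no number is known for it. Compound 3 `COc1cccc(-c2nc3cc(C)ccc3c(=O)[nH]2)c1` is the compound still to be measured. The change from compound 2 to compound 3 is methyl in place of trifluoromethyl on an oxygen on an aromatic ring. Among the measured compounds shown here, no step between measured compounds is available to size this change, so the expected step of a number no higher from compound 2 to compound 3 (the limit leaves the size open) in this assay is taken as small, within the usual scatter, with no direction to prefer. Compound 3 is therefore estimated at 50000 nM, within a range from 20000 nM to 120000 nM, and it may well return only a limit itself.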

Compound 3, half-maximal inhibitory concentration: 8940 nM
Estimate against measurement, compound 3: 5.6-fold (0.75 log units) above; measured number below the stated range.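

Replacing trifluoromethyl with methyl on an oxygen on an aromatic ring gives an at least 5.5-fold lower number from compound 2 to compound 3 (0.74 log units; beyond the scatter) in this assay. Among the compounds shown here, the earlier compounds offered no step at all, so this is the first evidence that the group carried on this oxygen can shift the read-out by more than the scatter. Only a lower bound on the step can be read, since compound 2 returns a limit rather than a number: the limit of > 50000 nM in this assay, at which 1 of the 3 values shown sits.

The compounds shown leave open whether the oxygen itself is needed, and whether a hydroxyl, an amine or a longer chain such as ethoxy at this place would lower the number further or raise it. They also leave open how far this step would hold on a different core, as it rests on a single pair of compounds.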